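The compounds below may be only part of what the source reports. "The series", "measured", "known", "first", "only" and "open" are said of these compounds alone.

Working notes on the series.

Going by the values given here, compound 2 `CCOc1ccc2c(Cl)ccnc2c1` carries the higher of the two numbers so far in a functional assay on RKO cells (Homo sapiens) for cytotoxicity, read by MTT assay, with a stated time of 48 h (a lower number here means a stronger inhibitor, a higher number a weaker inhibitor), where compound 2 gives 3870 nM. Among the compounds with values here, the only other measured member, compound 1 `CCCCCCOc1ccc2c(NCCN(C)C)ccnc2c1`, gives 1120 nM in this assay, a gap wider than the usual scatter; compound 1 and compound 2 differ in two places at once, so no single step between them is recorded.

Within the data shown here, the next compound, compound 3 `CCOc1ccc2c(NCCN(C)C)ccnc2c1`, keeps the ethoxy of compound 2 and changes only one group: (2-(dimethylamino)ethyl)amino in place of chloro on an aromatic carbon. Compound 1 already carries the entering group together with its lower number, which is the only pointer available. From the compounds shown here alone, the step from compound 2 to compound 3 is therefore expected to lower the number, by an amount that may or may not exceed the scatter, since the change in the other group is untested on its own. For compound 3 the expected step is a 2.4-fold lower number from compound 2 to compound 3 (0.38 log units; beyond the scatter). For compound 3 the estimate in this assay is 1600 nM, within 600 nM to 4200 nM.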

Compound 3, half-maximal inhibitory concentration: 3650 nM
Beside the measured number, compound 3's estimate is 2.3-fold (0.36 log units) below it; low and high end bracket the measured number.
By their numbers in this assay, from the lowest: compound 1; then compounds 3 and 2 (each within the scatter of the next).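

In this assay, with the ethoxy kept, (2-(dimethylamino)ethyl)amino in place of chloro on the aromatic carbon opposite the ring nitrogen gives a 1.1-fold lower number from compound 2 to compound 3 (0.03 log units; within the scatter) and so leaves the number unmoved at this position. The step that does register is a 3.3-fold higher number from compound 1 to compound 3 (0.51 log units; beyond the scatter) with hydrogen in place of butyl on a saturated chain carbon, two bonds along the chain from an oxygen on an aromatic ring, so with the amine group held constant the lower number goes with the longer chain. No measured property accounts for either step.

From the compounds shown here alone, whether the longer chain on the oxygen gives a similar step with chloro on the aromatic carbon remains open. So does the effect of a propoxy or octyloxy group on the oxygen, or of a morpholine in place of the (2-(dimethylamino)ethyl)amino group.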